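Trifluoromethyl on a Series That Sits at the Limit

This account rests on a few compounds, and the source may have more. Where it says the series, first, only, none or still open, it means among the compounds named here.

Compound 1, `CCc1cc2ccccc2nc1-c1cc(-c2ccccc2)no1`, gives > 100000 nM in a functional assay on MDA-MB-231 cells (Homo sapiens) for inhibition, read by MTT assay, with a stated time of 24 h (on this read-out higher numbers stand for weaker inhibition and lower numbers for stronger inhibition), which is a limit of the assay and not a number.
Compound 2, `CCCCc1cc2ccccc2nc1-c1cc(-c2ccccc2)no1`, gives > 100000 nM in this assay, again a limit.
Compound 3, `CCCCCc1cc2ccccc2nc1-c1cc(-c2ccccc2)no1`, gives > 100000 nM in this assay, also a limit.

Compound 2 therefore stands at the limit, and so do its two neighbours, as the limit of > 100000 nM in this assay, at which 3 of the 3 values shown sit, shows. The steps between the measured compounds, a step that the two limits leave unreadable from compound 1 to compound 2, a step that the two limits leave unreadable from compound 1 to compound 3 and a step that the two limits leave unreadable from compound 2 to compound 3, cannot be read, since a change between two limits has no size.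

Compound 4, `CCCCc1cc2ccccc2nc1-c1cc(-c2ccc(C(F)(F)F)cc2)no1`, differs from compound 2 by trifluoromethyl in place of hydrogen on an aromatic carbon. Within the data shown here, none of the measured steps bears on this change, and the measured steps themselves carry no readable size, so there is nothing in the numbers that would predict a move in this assay in either direction. The plain expectation is that compound 4 behaves like compound 2 and is expected to show a step of a number no higher from compound 2 to compound 4 (the limit leaves the size open), which is no step beyond the scatter. Compound 4 is accordingly expected to give about 100000 nM in this assay, with a range from 30000 nM to 300000 nM, most likely reported only as a limit again.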

Compound 4, half-maximal inhibitory concentration: 10400 nM
The estimate for compound 4 lay 9.6-fold (0.98 log units) above the measured number; the measured number lies below the stated range.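

In this assay, trifluoromethyl in place of hydrogen on an aromatic carbon, on the six-membered aromatic ring of carbon only and para to a large group, gives an at least 9.6-fold lower number from compound 2 to compound 4 (0.98 log units; beyond the scatter). The steps among compound 1, compound 2 and compound 3 all lie on the saturated chain and cannot be read, so this position on the ring is the only place in the compounds shown where a change registers as a readable step. Compound 4 is also the only compound shown with a real number rather than a limit, which gives the series a measured value to compare against: the limit of > 100000 nM in this assay, at which 3 of the 4 values shown sit.

From the compounds shown here alone, what remains open is whether the gain belongs to trifluoromethyl itself or whether another group at the same place, such as a chlorine atom, a methoxy group, an amine or a carboxylic acid, would do the same. It is also open whether trifluoromethyl at this place would give a readable number on the ethyl chain of compound 1 or the pentyl chain of compound 3, so the link between chain and ring substituent remains untested in the compounds shown.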